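A few compounds are considered here, and "the series" means these few. Any claim that something is new, unique, unknown or untested is made for them only; others in the source may bear on it.

Of the compounds shown here, three built on one shared core have been tested in a functional assay on HT-29 cells (Homo sapiens) for antiproliferative activity, read by sulforhodamine B assay, with a stated time of 48 h; on this read-out higher numbers stand for weaker inhibition and lower numbers for stronger inhibition. Compound 1 `O=C1NCCN1c1ccc(S(=O)(=O)Nc2cccc(Br)c2)cc1` gives 77 nM. Compound 2 `O=C1NCCN1c1ccc(S(=O)(=O)Nc2ccc(I)cc2)cc1` gives 650 nM. Compound 3 `Cc1cccc(NS(=O)(=O)c2ccc(N3CCNC3=O)cc2)c1C` gives 190 nM, the second highest of the three numbers. Every measured step is a swap of the whole aryl group on the sulfonamide nitrogen: an 8.4-fold higher number from compound 1 to compound 2 (0.93 log units; beyond the scatter), a 2.5-fold higher number from compound 1 to compound 3 (0.39 log units; beyond the scatter) and a 3.4-fold lower number from compound 2 to compound 3 (0.53 log units; beyond the scatter). Compound 4 `Cc1cccc(NS(=O)(=O)c2ccc(N3CCNC3=O)cc2)c1` differs from compound 3 by a much smaller change, (hydrogen in place of methyl on an aromatic carbon). Among the measured compounds shown here, no measured step removes a single methyl, so the three steps show only that reshaping this aryl group moves this assay by modest amounts in either direction. A change touching one carbon is expected to give a step no larger than those, and its direction cannot be read from the data. Accordingly the step expected here is a 1.3-fold higher number from compound 3 to compound 4 (0.12 log units; within the scatter). Compound 4 is therefore estimated at 250 nM, within a range from 80 nM to 800 nM.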

Compound 4, half-maximal inhibitory concentration: 110 nM
Beside the measured number, compound 4's estimate is 2.3-fold (0.36 log units) above it; low and high end bracket the measured number.
By their numbers in this assay, from the lowest: compounds 1, 4 and 3 (each within the scatter of the next, the first and the last beyond it); then compound 2.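

Taking one methyl off the 2,3-dimethylphenyl group to leave 3-methylphenyl is the first change of a single group on this aryl ring, and in this assay it gives a 1.7-fold lower number from compound 3 to compound 4 (0.24 log units; within the scatter) and so does not stand clear of the usual variation between repeats. Methyl in place of bromo gives a 1.4-fold higher number from compound 1 to compound 4 (0.15 log units; within the scatter), also too small to separate the two compounds, whereas 3-methylphenyl in place of 4-iodophenyl gives a 5.9-fold lower number from compound 2 to compound 4 (0.77 log units; beyond the scatter) and is a real difference. Nothing measured here explains any of these steps.

Going by these compounds, what a plain phenyl, 3-chlorophenyl or 3-aminophenyl group would give stays open, so it is unknown whether the remaining methyl is needed at all. On these data alone, whether a longer chain such as propyl could take the place of that methyl also remains open.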